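Trading a Methyl for Trifluoromethyl on the Benzyl Arm

A few compounds are considered here, and "the series" means these few. Any claim that something is new, unique, unknown or untested is made for them only; others in the source may bear on it.

Measured so far:
Compound 1 `Cc1cc(S(=O)(=O)/N=C(\N)n2nccc2-c2ccccc2)c(SCc2ccc(Cl)cc2)cc1Cl`: 3000 nM
Compound 2 `Cc1cc(-c2ccccc2)n(/C(N)=N/S(=O)(=O)c2cc(C)c(Cl)cc2SCc2ccccc2C(F)(F)F)n1`: 215000 nM
Compound 3 `Cc1cccc(CSc2cc(Cl)c(C)cc2S(=O)(=O)/N=C(\N)n2nccc2-c2ccccc2)c1`: 8000 nM

Of the compounds shown here, three sharing one core have been tested in a functional assay on HeLa cells (Homo sapiens) for cytotoxicity, read by MTT assay, with a stated time of 72 h; on this read-out higher numbers stand for weaker inhibition and lower numbers for stronger inhibition. Compound 3 gives 8000 nM and stands second highest of the three numbers. Within the data shown here, its nearest neighbour is compound 1, which gives 3000 nM; the one step between them, a 2.7-fold higher number from compound 1 to compound 3 (0.43 log units; beyond the scatter), is modest but beyond the scatter. Compound 2, which gives 215000 nM, differs from compound 3 in more than one place, so its much higher number cannot be tied to a single change.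

The next compound, compound 4 `Cc1cc(S(=O)(=O)/N=C(\N)n2nccc2-c2ccccc2)c(SCc2ccc(C(F)(F)F)cc2)cc1Cl`, differs from compound 3 only on the benzyl arm: 4-(trifluoromethyl)phenyl in place of 3-methylphenyl on a saturated chain carbon bound to a sulfur. Among the measured compounds shown here, the only step that bears on it is a 2.7-fold higher number from compound 1 to compound 3 (0.43 log units; beyond the scatter), where swapping a 4-chlorophenyl for a 3-methylphenyl raised the number. Compound 4 returns to a group placed like that of compound 1, so a modest fall back toward compound 1 is expected, a 2.0-fold lower number from compound 3 to compound 4 (0.30 log units; within the scatter). Compound 4 is therefore estimated at 4000 nM, with a range from 1500 nM to 12000 nM.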

Compound 4, half-maximal inhibitory concentration: 17000 nM
Compound 4: middle estimate off by 4.3-fold (0.63 log units), on the low side, and the stated range ends below it.
By their numbers in this assay, from the lowest: compound 1; then compound 3; then compound 4; then compound 2.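

In this assay, the move to 4-(trifluoromethyl)phenyl on the benzyl arm gives a 2.1-fold higher number from compound 3 to compound 4 (0.33 log units; beyond the scatter), so this group does not bring the number back toward that of compound 1. Compound 1 and compound 4 differ only by trifluoromethyl in place of chloro on an aromatic carbon, and that single change gives a 5.7-fold higher number from compound 1 to compound 4 (0.75 log units; beyond the scatter), which shows that the identity of the group at this ring place matters on its own, whatever the effect of moving it. Nothing available explains why the trifluoromethyl compound gives the higher number.

From the compounds shown here alone, it remains open whether fluoro, methoxy or an amine at the same ring place would stay near compound 1 or drift toward compound 4. Also open, going by these compounds, is how a longer chain between the sulfur and the ring would behave.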